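The compounds below may be only part of what the source reports. "The series", "measured", "known", "first", "only" and "open" are said of these compounds alone.

Measured compounds:
- compound 1 `Cc1cc(Oc2ncc(C(F)(F)F)cc2Cl)ccc1CC1SC(=O)NC1=O`: 10 nM
- compound 2 `Cc1ccnc(Oc2ccc(CC3SC(=O)NC3=O)cc2)c1`: 4280 nM
- compound 3 `Cc1cc(Oc2ncc(C(F)(F)F)cc2Cl)cc(C)c1CC1SC(=O)NC1=O`: 5450 nM

In a functional assay for agonist activity at Free fatty acid receptor 1 (Homo sapiens), read by FLIPR, in the presence of a further agent that is not named here (a lower number here means that less compound is needed, a higher number that more compound is needed for the effect), compound 1 gives 10 nM, the lowest number of the three; compound 2 gives 4280 nM and compound 3 gives 5450 nM, both far higher. For the measured compounds named here, the single counted step, a 550-fold higher number from compound 1 to compound 3 (2.74 log units; beyond the scatter), shows that a change on the ring bearing the (2,4-dioxo-1,3-thiazolidin-5-yl)methyl group can move this assay a long way.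

Compound 4 `COc1cc(Oc2ncc(C(F)(F)F)cc2Cl)ccc1CC1SC(=O)NC1=O` differs from compound 1 by methoxy in place of methyl on an aromatic carbon. Going by the values given here, no measured pair tells what a methoxy does at this position; the step from compound 1 to compound 3 bears on it only in that it marks this ring as sensitive to substitution, and it added a group rather than exchanging one. A moderate loss is therefore expected, with wide uncertainty. Compound 4 is estimated at 30 nM (range 5 nM to 250 nM), a step of a 3.0-fold higher number from compound 1 to compound 4 (0.48 log units; beyond the scatter) that is expected rather than known.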

Compound 4, half-maximal effective concentration: 13900 nM
For compound 4 the middle estimate is 460-fold (2.67 log units) below the measured one; measured number above the stated range.
By their numbers in this assay, from the lowest: compound 1; then compounds 2 and 3 (each within the scatter of the next); then compound 4.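

In this assay, methoxy in place of methyl ortho to the (2,4-dioxo-1,3-thiazolidin-5-yl)methyl group gives a 1400-fold higher number from compound 1 to compound 4 (3.14 log units; beyond the scatter), so this carbon does not accept every small group and the exchange of one group for another can cost as much as an addition. The earlier step, a 550-fold higher number from compound 1 to compound 3 (2.74 log units; beyond the scatter), came from adding a methyl on this ring; the new step shows that the sensitivity of the ring also reaches the carbon that carries the methyl in compound 1. Nothing available explains why the methoxy has so large an effect.

As far as these compounds go, what hydrogen, chlorine or a hydroxy group would do at this carbon remains open. So does the question of whether the methyl itself is needed for compound 1 to reach 10 nM, or whether methoxy is a specific exception at this position.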